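Methoxycarbonyl in place of methylsulfonyl on the shared core

This account rests on a few compounds, and the source may have more. Where it says the series, first, only, none or still open, it means among the compounds named here.

Of the compounds shown here, two with a shared core have been measured in an ADME assay on SK-N-BE(2)-M17 cells (Homo sapiens) for cytotoxicity; a higher number here means that more compound is tolerated, a lower number that less compound is tolerated. Compound 1 `CC1=CC(C)(C)Nc2c(C(=O)N[C@@H](C)/C=C/S(C)(=O)=O)cccc21` reads > 25000 nM, which is a limit of the assay and not a number. Within the data shown here, compound 2 `CC1=CC(C)(C)Nc2c(C(=O)NC/C=C/S(C)(=O)=O)cccc21` gives 19600 nM, the only actual number so far, so it has no fully measured neighbour to be ranked against. Among the measured compounds shown here, the one measured step, an at least 1.2-fold lower number from compound 1 to compound 2 (0.10 log units; that floor lies within the scatter), lies within the scatter and concerns a different part of the chain.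

Compound 3 `COC(=O)/C=C/CNC(=O)c1cccc2c1NC(C)(C)C=C2C` departs from compound 2 at the end of that chain: methoxycarbonyl in place of methylsulfonyl on a double-bonded chain carbon bound to a double-bonded chain carbon. The change is methoxycarbonyl in place of methylsulfonyl, on a double-bonded chain carbon bound to a double-bonded chain carbon. For the measured compounds named here, no measured step covers this exchange, so the forecast rests on compound 2 at 19600 nM and on the small size of the step of an at least 1.2-fold lower number from compound 1 to compound 2 (0.10 log units; that floor lies within the scatter). No shift beyond the scatter is therefore expected in this assay, and the estimated step is a 1.1-fold lower number from compound 2 to compound 3 (0.04 log units; within the scatter). For compound 3 the expected value is 18000 nM, with an estimated range from 8000 nM to 40000 nM.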

Compound 3, half-maximal cytotoxic concentration: 18100 nM
Beside the measured number, compound 3's estimate is 1.0-fold (0.00 log units) below it; the measured number falls inside the stated range.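

In this assay, among these compounds, this is the first reading at the far end of the chain: methoxycarbonyl in place of methylsulfonyl on a double-bonded chain carbon bound to a double-bonded chain carbon gives a 1.1-fold lower number from compound 2 to compound 3 (0.03 log units; within the scatter), so the two end groups cannot be told apart here, and this position now carries two actual numbers rather than one. The wider step, an at least 1.3-fold lower number from compound 1 to compound 3 (0.14 log units; that floor lies within the scatter), joins that exchange to the change in the methyl on the chain and can be read only as a floor, which adds nothing beyond the scatter. Compound 1 stands at a limit of the assay, which is not a number, so how far either step really reaches stays unknown: the limit of > 25000 nM in this assay, at which 1 of the 3 values shown sits.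

What the compounds shown leave open is whether any end group at this place moves the number beyond the scatter, as a carboxylic acid, a primary amide or a nitrile might test. Also open, from the compounds shown here alone, is whether a methyl on the saturated chain carbon bound to the amide-type nitrogen would read the same with methoxycarbonyl at the end of the chain.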